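The source may hold more compounds than are shown below. What is called first, only, known or untested is meant among the compounds shown, and "the series" means these compounds.

Compound 1, `Cc1cc(-c2ccc(Cl)cc2Cl)c(S(C)(=O)=O)cc1C(=O)N=C(N)N`, gives 42 nM in a functional assay for inhibition of sodium/hydrogen exchanger (Oryctolagus cuniculus); a lower number here means a stronger inhibitor, a higher number a weaker inhibitor.
Compound 2, `Cc1cc(OC2CCCC2)c(S(C)(=O)=O)cc1C(=O)N=C(N)N`, gives 27 nM in this assay.
Compound 3, `Cc1cc(N)c(S(C)(=O)=O)cc1C(=O)N=C(N)N`, gives 16 nM in this assay.

Among the three measured compounds, compound 3 has the lowest number in this assay. Its step from compound 2, a 1.7-fold lower number from compound 2 to compound 3 (0.23 log units; within the scatter), lies within the scatter, while the step from compound 1, a 2.6-fold lower number from compound 1 to compound 3 (0.42 log units; beyond the scatter), lies beyond it. The three share one core and differ only at a single aromatic carbon, which carries 2,4-dichlorophenyl in compound 1, cyclopentyloxy in compound 2 and amino in compound 3.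

Compound 4, `Cc1cc(Nc2ccccc2)c(S(C)(=O)=O)cc1C(=O)N=C(N)N`, has not yet been measured. It differs from compound 3 by phenyl in place of hydrogen on a nitrogen on an aromatic ring. Within the data shown here, no measured step alters this nitrogen itself; the closest comparisons are the steps at the aromatic carbon, a 2.6-fold lower number from compound 1 to compound 3 (0.42 log units; beyond the scatter) and a 1.7-fold lower number from compound 2 to compound 3 (0.23 log units; within the scatter), where a 2,4-dichlorophenyl group and a cyclopentyloxy group stood in place of amino. Both gave higher numbers than compound 3, the aromatic group more so. Compound 4 places a phenyl one bond further out, on the nitrogen, a related but not identical change. Among the measured compounds shown here, the number for compound 4 is therefore expected to rise modestly from compound 3, a 1.9-fold higher number from compound 3 to compound 4 (0.27 log units; within the scatter), with wide uncertainty since only one measured comparison, compound 1, involves an aromatic group. Compound 4 is estimated at 30 nM, within a range from 12 nM to 80 nM.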

Compound 4, half-maximal inhibitory concentration: 21 nM
Beside the measured number, compound 4's estimate is 1.4-fold (0.15 log units) above it; measured number inside the range.
By their numbers in this assay, from the lowest: compounds 3, 4, 2 and 1 (each within the scatter of the next, the first and the last beyond it).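

Among these compounds, putting a phenyl on the nitrogen of the amino group is the first change to that nitrogen itself, and in this assay it stays within the scatter (a 1.3-fold higher number from compound 3 to compound 4 (0.12 log units; within the scatter)), so this aromatic carbon accepts the larger anilino group with no change that the assay can resolve. The anilino group also cannot be separated from the two larger groups seen earlier, either from cyclopentyloxy (a 1.3-fold lower number from compound 2 to compound 4 (0.11 log units; within the scatter)) or from 2,4-dichlorophenyl (a 2.0-fold lower number from compound 1 to compound 4 (0.30 log units; within the scatter)), so compound 4 stands within the scatter of compounds 1, 2 and 3 even though compounds 1 and 3 differ beyond it. Nothing measured here explains this outcome.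

The compounds shown leave open whether a chlorine or a methoxy group on the phenyl ring of the anilino group would move the number, given that compound 4 carries an unsubstituted ring. They also leave open what a methyl group or a longer alkyl chain on this nitrogen would do, whether in place of the phenyl or in place of the remaining hydrogen on the nitrogen of compound 4.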